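Chain extension to the behenoyl analogue

This account rests on a few compounds, and the source may have more. Where it says the series, first, only, none or still open, it means among the compounds named here.

Measured compounds:
compound 1 `CCCCCCCCCCCCCC(=O)NC(CCC(=O)O)(CCC(=O)O)CCC(=O)O`: 300000 nM
compound 2 `CCCCCCCCCCCCCCCCNC(=O)NC(CCC(=O)O)(CCC(=O)O)CCC(=O)O`: 350000 nM
compound 3 `CCCCCCCCCCCCCCCC(=O)NC(CCC(=O)O)(CCC(=O)O)CCC(=O)O`: 940000 nM

In an ADME assay on cells (Epithelial cell, Homo sapiens) for cytotoxicity, read by MTT assay (on this read-out lower numbers stand for an effect already at smaller amounts and higher numbers for an effect only at larger amounts of compound), compound 3 holds the highest number of the three; compound 2 and compound 1 both sit beyond the scatter below it. Compound 4 `CCCCCCCCCCCCCCCCCCCCCC(=O)NC(CCC(=O)O)(CCC(=O)O)CCC(=O)O` is not yet measured in this assay. It differs from compound 3 by hexyl in place of hydrogen on a saturated chain carbon, ten or more bonds along the chain from a carbonyl carbon.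

Within the data shown here, one measured step bears on this: a 3.1-fold higher number from compound 1 to compound 3 (0.50 log units; beyond the scatter), which is the same kind of change, a shorter extension of the saturated chain at the same place. Among the measured compounds shown here, on that basis a further lengthening is expected to shift the number in the same direction, upward, though the one step gives no ground to assume the shift continues in proportion over a longer extension, so the expected step is modest: a 1.6-fold higher number from compound 3 to compound 4 (0.20 log units; within the scatter). Compound 4 is therefore estimated at 1500000 nM in this assay, with a range from 500000 nM to 5000000 nM.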

Compound 4, half-maximal effective concentration: 250000 nM
The estimate for compound 4 lay 6.0-fold (0.78 log units) above the measured number; the whole stated range lies above it.
By their numbers in this assay, from the lowest: compounds 4, 1 and 2 (each within the scatter of the next); then compound 3.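

At this place on the saturated chain, lengthening does not act in one direction: in this assay, the rise of a 3.1-fold higher number from compound 1 to compound 3 (0.50 log units; beyond the scatter) is followed, with hexyl in place of hydrogen, by a 3.8-fold lower number from compound 3 to compound 4 (0.58 log units; beyond the scatter). The octyl change taken as a whole gives a 1.2-fold lower number from compound 1 to compound 4 (0.08 log units; within the scatter), so compound 1 and compound 4 cannot be told apart, and among these three amides only compound 3 stands clear of the others. Nothing at hand bears on why the direction turns.

Among these compounds, with only three chain lengths, it remains open whether compound 3 marks a true maximum or whether chains of intermediate length would stand higher still. Also open, on these data alone, is how a longer chain, or a chain ending in an amine or a carboxylic acid, would read at this place.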